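Aryl replacement next to the ring oxygen: forecast for compound 4

The compounds below may be only part of what the source reports. "The series", "measured", "known", "first", "only" and "open" are said of these compounds alone.

Compound 1 `CCC1=C(O)c2c(oc(-c3ccc(C(C)C)cc3)cc2=O)C(CC)(CC)C1=O` carries the 4-isopropylphenyl group and, in a functional assay on KB cells (Homo sapiens) for antiproliferative activity, read by sulforhodamine B assay, with a stated time of 3 days (a lower number here means that less compound is needed, a higher number that more compound is needed for the effect), compound 1 gives 8.13 uM. Among the two numbers at hand this is the lowest; the nearest is compound 3 `CCC1=C(O)c2c(oc(-c3cccc(C(F)(F)F)c3)cc2=O)C(CC)(CC)C1=O`, which in this assay gives 35.7 uM, a gap beyond the scatter. Compound 2 `CCC1=C(O)c2c(oc(-c3ccc(CBr)cc3)cc2=O)C(CC)(CC)C1=O` gives only a limit, > 46.5 uM, in this assay. The step of an at least 5.7-fold higher number from compound 1 to compound 2 (0.75 log units; beyond the scatter) is therefore only a lower bound, due to the limit of > 46.5 uM in this assay, at which 1 of the 3 values shown sits.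

Compound 4 `CCC1=C(O)c2c(oc(-c3ccc(C)c(F)c3)cc2=O)C(CC)(CC)C1=O` has not yet been measured in this assay. It differs from compound 1 by 3-fluoro-4-methylphenyl in place of 4-isopropylphenyl on an aromatic carbon. For the measured compounds named here, no measured step matches this change exactly. The two changes to the pendant aryl group that have been measured both gave higher numbers: bromomethyl in place of isopropyl, at least modest, and the comparison of compound 1 with compound 3, where the trifluoromethyl-bearing aryl group is the weaker of the two beyond the scatter. On that basis a modest rise in the number is expected for compound 4, short of the limit, with a 2.2-fold higher number from compound 1 to compound 4 (0.35 log units; beyond the scatter) as the estimated step. Compound 4 is therefore estimated at 18 uM in this assay, within a range from 7 uM to 46 uM.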

Compound 4, concentration for half-maximal effect: 28.1 uM
Compound 4: middle estimate off by 1.6-fold (0.19 log units), on the low side; the range from low to high includes it.
By their numbers in this assay, from the lowest: compound 1; then compounds 4 and 3 (each within the scatter of the next). At a limit, above all of these: compound 2.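

In this assay, for the compounds shown here, the change to the 3-fluoro-4-methylphenyl group gives the first fully measured step at this position next to the ring oxygen: a 3.5-fold higher number from compound 1 to compound 4 (0.54 log units; beyond the scatter). Unlike the step to compound 2, this one has a definite size, and it shows that a replacement keeping an alkyl group on the aryl ring, here a methyl alongside a fluorine, still does not hold the number of compound 1, which stays the lowest of the measured values in the series. The second new step, an at least 1.6-fold lower number from compound 2 to compound 4 (0.21 log units; that floor lies within the scatter), cannot be read as an order between the two compounds, and its floor is all that is available, due to a limit: the limit of > 46.5 uM in this assay, at which 1 of the 4 values shown sits.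

The compounds shown do not separate the contribution of the fluorine from that of replacing isopropyl with methyl, a split that 4-methylphenyl and 3-fluoro-4-isopropylphenyl groups would make. Going by these compounds, it also remains open how this position responds to a longer alkyl chain, such as butyl, or to an amine or a carboxylic acid on the aryl ring.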